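The source may hold more compounds than are shown below. What is called first, only, known or untested is meant among the compounds shown, and "the series" means these compounds.

In an ADME assay on L02 cells (Homo sapiens) for cytotoxicity, read by MTT assay, with a stated time of 48 h (a lower number here means a stronger inhibitor, a higher number a weaker inhibitor), compound 1 `CCN(CC)CCCNC(=O)c1ccc(C(CC)(CC)c2ccc(OCC(O)C(C)(C)C)c(C)c2)n1CC` gives 2500 nM and compound 2 `CCn1c(C(=O)N(C)CCC#N)ccc1C(CC)(CC)c1ccc(OCC(O)C(C)(C)C)c(C)c1` gives 14900 nM, the higher of the two numbers. Compound 3 `CCn1c(C(=O)OCc2ccc(F)cc2)ccc1C(CC)(CC)c1ccc(OCC(O)C(C)(C)C)c(C)c1` keeps the shared core and changes only the group on the carbonyl carbon: (4-fluorobenzyl)oxy in place of (2-cyanoethyl)(methyl)amino on a carbonyl carbon. Within the data shown here, the one measured step at that carbon is a 6.0-fold higher number from compound 1 to compound 2 (0.78 log units; beyond the scatter), a modest step between a different pair of groups, so it indicates no direction for this exchange. A shift no larger than that one is expected, and the estimated step is a 1.2-fold lower number from compound 2 to compound 3 (0.09 log units; within the scatter). For compound 3 the expected value is 12000 nM, with an estimated range of 4500 nM to 32000 nM.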

Compound 3, half-maximal inhibitory concentration: 14900 nM
Compound 3: middle estimate off by 1.2-fold (0.09 log units), on the low side; the range from low to high includes it.
By their numbers in this assay, from the lowest: compound 1; then compounds 2 and 3 (each within the scatter of the next).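

In this assay, (4-fluorobenzyl)oxy in place of (2-cyanoethyl)(methyl)amino on the carbonyl carbon gives no change at the digits printed from compound 2 to compound 3 (within the scatter), so two groups with no shared atoms beyond carbon stand level at this position. Among these compounds, the step of a 6.0-fold higher number from compound 1 to compound 3 (0.78 log units; beyond the scatter) leaves (3-(diethylamino)propyl)amino in compound 1 as the only group of the three apart from the others. No supporting measurement bears on this result.

Open, as far as these compounds go, is whether the lower number of compound 1 tracks its diethylamino group or its amide hydrogen. A simple primary amide or a carboxylic acid on the carbonyl carbon would help separate these.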